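Replacing 2-fluorophenyl of compound 2 with 3-cyanophenyl

The compounds below may be only part of what the source reports. "The series", "measured", "known", "first", "only" and "open" are said of these compounds alone.

In a functional assay on MKN-45 cells (Homo sapiens) for inhibition, read by CCK-8 assay, with a stated time of 24 h (a lower number here means a stronger inhibitor, a higher number a weaker inhibitor), compound 1 (`O=C1Nc2ccccc2/C1=C/c1ccc(-c2cn(-c3ccccc3F)nn2)cc1`) gives a half-maximal inhibitory concentration of 12500 nM and compound 2 (`O=C1Nc2ccc(F)cc2/C1=C/c1ccc(-c2cn(-c3ccccc3F)nn2)cc1`) gives 8510 nM on the same read-out. Compound 3 (`N#Cc1ccccc1-n1cc(-c2ccc(C=C3C(=O)Nc4ccc(F)cc43)cc2)nn1`) gives 15200 nM in this series. Compound 2 lies within the scatter of both other compounds, so its place among the three numbers sets up no ranking.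

Compound 4 (`N#Cc1cccc(-n2cc(-c3ccc(/C=C4\C(=O)Nc5ccc(F)cc54)cc3)nn2)c1`) keeps the core of compound 2 and carries 3-cyanophenyl in place of 2-fluorophenyl on an aromatic nitrogen. Going by the values given here, the one measured step is a 1.5-fold lower number from compound 1 to compound 2 (0.17 log units; within the scatter) and it concerns fluoro in place of hydrogen on an aromatic carbon, not the group that changes here. The closer evidence is compound 3, which shares the core of compound 2 and also has a nitrile on the phenyl group at that nitrogen. Compound 3 at 15200 nM and compound 2 at 8510 nM lie within the scatter of each other. Among the compounds with values here, no measured compound carries 3-cyanophenyl itself, so the estimate stays broad, and no step beyond the scatter is expected in this assay in either direction. The expected change is a 1.3-fold higher number from compound 2 to compound 4 (0.11 log units; within the scatter) and no more. For compound 4 the estimated value is 11000 nM with an expected range from 4500 nM to 25000 nM in this assay.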

Compound 4, half-maximal inhibitory concentration: > 20000 nM
Compound 4: only a limit was reported; the forecaster's own chance of this, stated with the estimate: 8%; middle value at least 1.8-fold (0.25 log units) from the limit.
By their numbers in this assay, from the lowest: compounds 2, 1 and 3 (each within the scatter of the next). At a limit, above all of these: compound 4.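

In this assay compound 4 gives > 20000 nM, which is a limit of the assay and not a number. Putting 3-cyanophenyl in place of 2-fluorophenyl on the aromatic nitrogen of the five-membered ring is the only change shown that gives a step beyond the scatter: an at least 2.3-fold higher number from compound 2 to compound 4 (0.37 log units; beyond the scatter). This shows that the group on this nitrogen can move the reading in a way that the fluoro change on the shared core did not, although the size of the step is only a lower bound because compound 4 stands at a limit: the limit of > 20000 nM in this assay, at which 1 of the 4 values shown sits.

From the compounds shown here alone, what remains open is how far compound 4 really lies from compound 2, and whether the placing of the nitrile on the phenyl group matters, since compound 3 also carries a nitrile there and a limit cannot be ranked closely against a measured number. The compounds shown also leave open how this nitrogen would tolerate a phenyl group bearing an amine, a carboxylic acid or a methoxy group, or an unsubstituted phenyl group.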